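Moving the fluorine from compound 2 to compound 3

A few compounds are considered here, and "the series" means these few. Any claim that something is new, unique, unknown or untested is made for them only; others in the source may bear on it.

Compound 1 `Cc1ccnc(NC(c2ccc(C(F)(F)F)cc2)c2ccc3cccnc3c2O)c1`: 2100 nM
Compound 2 `Cc1ccnc(NC(c2ccccc2F)c2ccc3cccnc3c2O)c1`: 13100 nM

Among the compounds with values here, in a functional assay on U-87MG ATCC cells for inhibition, with U-87 MG (Homo sapiens) as the target, read by MTT assay, with a stated time of 72 h (on this read-out higher numbers stand for weaker inhibition and lower numbers for stronger inhibition), compound 2 holds the higher of the two numbers so far, 13100 nM. Compound 3 `Cc1ccnc(NC(c2ccc(F)cc2)c2ccc3cccnc3c2O)c1` carries 4-fluorophenyl in place of 2-fluorophenyl on a saturated chain carbon bound to an aromatic carbon and a nitrogen on an aromatic ring. Within the data shown here, only one measured step bears on this, and only loosely: a 6.2-fold higher number from compound 1 to compound 2 (0.80 log units; beyond the scatter). Among the measured compounds shown here, that step swaps 4-(trifluoromethyl)phenyl for 2-fluorophenyl, so a single pair is the only guide and no pattern can be claimed. The name of the incoming group resembles that of compound 1, so a move part of the way towards 2100 nM seems reasonable. The expected change is a 2.2-fold lower number from compound 2 to compound 3 (0.34 log units; beyond the scatter), a modest shift towards stronger inhibition in this assay. Compound 3 is estimated at 6000 nM, with an expected range of 2500 nM to 14000 nM.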

Compound 3, half-maximal inhibitory concentration: > 10000 nM
Compound 3: only a limit was reported (the forecaster's own chance of this, stated with the estimate: 3%); middle value at least 1.6-fold (0.22 log units) away from the limit.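

In this assay compound 3 gives > 10000 nM, which is a limit of the assay and not a number. Even so, one comparison can be read: fluoro in place of trifluoromethyl on an aromatic carbon gives an at least 4.7-fold higher number from compound 1 to compound 3 (0.67 log units; beyond the scatter), so of these two groups, trifluoromethyl goes with the stronger inhibition in this pair. Whether 4-fluorophenyl differs from 2-fluorophenyl on the saturated chain carbon cannot be read, because one side of that comparison is only a limit: the limit of > 10000 nM in this assay, at which 1 of the 3 values shown sits.

On these data alone, it therefore remains open whether moving the fluorine around the ring changes inhibition at all. A plain phenyl or a methoxyphenyl group on the same carbon would help show whether the stronger inhibition of compound 1 is tied to trifluoromethyl itself.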